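Swapping a Nitrile for Fluorine on a Biphenyl Tail

The source may report more compounds than this note shows. Statements on the series, on what has been measured and on what is new or still open speak of the compounds shown alone.

Compound 2 `Cc1cc(-c2ccc(C#N)cc2)cc(C)c1Oc1nc(Nc2ccc(C#N)c(F)c2)nc2sccc12` shares its core with compound 3 `Cc1cc(-c2ccc(C#N)cc2)cc(C)c1Oc1nc(Nc2ccc(C#N)nc2)nc2sccc12` and compound 1 `N#C/C=C/c1cc(F)c(Oc2nc(Nc3ccc(C#N)nc3)nc3sccc23)c(F)c1`. In a toxicity assay on MT4 cells (Homo sapiens) for cytotoxicity, read by MTT assay, with a stated time of 5 days (a lower number here means that less compound is tolerated, a higher number that more compound is tolerated), compound 2 gives only a limit of the assay, > 254000 nM, so its true number is not known. Compound 3 gives 181000 nM in this assay, and compound 1 gives 12800 nM. For the measured compounds named here, the one measured step alters a different part of the molecule: an at least 1.4-fold lower number from compound 2 to compound 3 (0.14 log units; that floor lies within the scatter). Compound 4 `Cc1cc(-c2ccc(F)cc2)cc(C)c1Oc1nc(Nc2ccc(C#N)c(F)c2)nc2sccc12` differs from compound 2 as follows: fluoro in place of cyano on an aromatic carbon. Going by the values given here, no measured step touches this position, so no size can be borrowed from them. Compound 4 is expected to stay close to its parent, giving an at least 1.2-fold lower number from compound 2 to compound 4 (0.10 log units; that floor lies within the scatter). Compound 4 is therefore estimated at 200000 nM, ranging from 80000 nM to 400000 nM, with a fair chance of again reaching only a limit.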

Compound 4, half-maximal cytotoxic concentration: 28900 nM
Beside the measured number, compound 4's estimate is 6.9-fold (0.84 log units) above it; measured number outside the range, below it.
By their numbers in this assay, from the lowest: compound 1; then compound 4; then compound 3. At a limit, above all of these: compound 2.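

This position is not a silent one: in this assay, changing 4-cyanophenyl to 4-fluorophenyl gives an at least 8.7-fold lower number from compound 2 to compound 4 (0.94 log units; beyond the scatter), so less compound is tolerated. The earlier step, made at another place, had a floor that stayed within the scatter, whereas this floor lies beyond it. The true size remains unknown, as the value for compound 2 is a limit and not a number: the limit of > 254000 nM in this assay, at which 1 of the 4 values shown sits.

Only cyano and fluoro are seen on this aromatic carbon. From the compounds shown here alone, it remains open whether plain hydrogen, an amine or a carboxylic acid there would be tolerated more like compound 2 or like compound 4.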